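The source may report more compounds than this note shows. Statements on the series, on what has been measured and on what is new or still open speak of the compounds shown alone.

Compound 1 `CNC(=O)c1ccc(Sc2ccc(NC(=S)Nc3ccc(Cl)cc3)cc2)nc1` and compound 3 `CNC(=O)c1ccc(Sc2cccc(NC(=S)Nc3ccc(Cl)cc3)c2)nc1` are built from the same atoms joined differently; the difference between the two cores is not broken down here. Compound 2 `CNC(=O)c1ccc(Sc2cccc(NC(=S)Nc3ccc(OC(F)(F)F)cc3)c2)nc1` shares its core with compound 3, and compound 4 `CNC(=O)c1ccc(Sc2ccc(NC(=S)Nc3ccc(OC(F)(F)F)cc3)cc2)nc1` shares its core with compound 1.

In a functional assay on HCT-116 cells (Homo sapiens) for cytotoxicity, read by MTT assay, with a stated time of 48 h (a higher number here means a weaker inhibitor, a lower number a stronger inhibitor), compound 1 gives 34500 nM. In this assay compound 3 gives 39500 nM, and compound 2 gives 24500 nM. Among the three measured compounds no pair is separated by more than the usual scatter of repeated measurements, so no order can be read from them.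

One change appears twice. From compound 3 to compound 2 it is trifluoromethoxy in place of chloro on an aromatic carbon, and it produced a 1.6-fold lower number from compound 3 to compound 2 (0.21 log units; within the scatter). From compound 1 to compound 4 it is trifluoromethoxy in place of chloro on an aromatic carbon. The two place descriptions match word for word, so the change is the same one, carried onto the core of compound 1 instead of the core of compound 3.

Among the compounds with values here, for compound 4 the step is expected to be of the same modest size, a 1.6-fold lower number from compound 1 to compound 4 (0.20 log units; within the scatter), because the one earlier measurement of this change, a 1.6-fold lower number from compound 3 to compound 2 (0.21 log units; within the scatter), stayed within the scatter. The expectation rests on that single pair and on nothing else. Compound 4 is therefore estimated at 22000 nM in this assay, with a likely range from 11000 nM to 44000 nM.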

Compound 4, half-maximal inhibitory concentration: > 100000 nM
Compound 4 was reported as a limit; the forecaster's own chance of this, stated with the estimate: 5%; middle value at least 4.5-fold (0.65 log units) from the limit.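

In this assay, trifluoromethoxy in place of chloro gave an at least 2.8-fold higher number from compound 1 to compound 4 (0.46 log units; beyond the scatter), so the earlier step did not carry over from the core of compound 3 to the core of compound 1, and the two steps differ: the same change on two cores in this assay, a 1.6-fold lower number (0.21 log units; within the scatter) from compound 3 to compound 2 and an at least 2.8-fold higher number (0.46 log units; beyond the scatter) from compound 1 to compound 4, at least 4.6-fold (0.66 log units) apart, beyond the scatter of two such steps Compound 4 gives > 100000 nM, which is a limit of the assay and not a number, so the direction of its step is known but its full size is not: the limit of > 100000 nM in this assay, at which 1 of the 4 values shown sits. Each core contributes only one pair, so the result shows that the outcome of this one change depended on the core among these four compounds, but it does not show why, nor whether any other change would depend on the core in the same way.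

As far as these compounds go, it remains open whether a methoxy group, a methyl group or an amine in place of chloro, on the same aromatic carbon para to a large group, would also give different outcomes on the two cores. From the compounds shown here alone, it is equally open whether a longer chain, such as ethyl, in place of the methyl group on the amide nitrogen would change the picture on either core.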